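A few compounds are considered here, and "the series" means these few. Any claim that something is new, unique, unknown or untested is made for them only; others in the source may bear on it.

Measured in a functional assay on PC-3 cells (Homo sapiens) for antiproliferative activity, read by MTT assay, with a stated time of 48 h; a higher number here means a weaker inhibitor of growth, a lower number a stronger inhibitor of growth:
- compound 1 `CCOc1cc(NC(=O)CCCCCCC(=O)Nc2ccccc2N)cc2c1OCC([N+](=O)[O-])=C2`: 8630 nM
- compound 2 `CCOc1cc(NC(=O)CCCCC(=O)Nc2ccccc2N)cc2c1OCC([N+](=O)[O-])=C2`: 18900 nM

Compound 2 stands higher of the two at 18900 nM in this assay, with compound 1 lower by a margin beyond the scatter.

Compound 3 `CCOc1cc(NC(=O)CCCCCC(=O)Nc2ccccc2N)cc2c1OCC([N+](=O)[O-])=C2` carries ((2-aminophenyl)carbamoyl)methyl in place of (2-aminophenyl)carbamoyl on a saturated chain carbon, four bonds along the chain from a carbonyl carbon.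

In this assay a small fall in the number is expected, probably not beyond the scatter, with compound 1 at 8630 nM as the likely lower reference. The estimated change is a 1.5-fold lower number from compound 2 to compound 3 (0.18 log units; within the scatter). For compound 3 the expected value is 12500 nM, with an estimated range of 7000 nM to 21000 nM.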

Compound 3, concentration for 50% growth inhibition: > 20000 nM
Compound 3 was reported as a limit (the forecaster's own chance of this, stated with the estimate: 2%); at least 1.6-fold (0.20 log units) between middle value and limit.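

In this assay compound 3 gives > 20000 nM, a limit and not a number. The change in chain length reads as an at least 1.0-fold higher number from compound 2 to compound 3 (0.02 log units; that floor lies within the scatter), so no order can be set for that pair, while the further change reads as an at least 2.3-fold higher number from compound 1 to compound 3 (0.36 log units; beyond the scatter). Compound 3 therefore does not show the expected small fall in the number, and the gain seen with compound 1 does not extend to this intermediate chain.

On these data alone, the true value of compound 3 remains unknown. Also open, as far as these compounds go, are the effects of a longer chain than that of compound 1 and of a hydroxamic acid in place of the (2-aminophenyl)carbamoyl group.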